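The source may hold more compounds than are shown below. What is called first, only, known or untested is meant among the compounds shown, and "the series" means these compounds.

Three compounds share one core and differ only in the group on the outer benzene ring. Compound 1 `COc1ccc(Nc2nc(NCCCO)c3ccccc3n2)cc1` carries a methoxy group and gives 20300 nM in a functional assay on KB cells (Homo sapiens) for antiproliferative activity, read by sulforhodamine B assay, with a stated time of 48 h; on this read-out higher numbers stand for weaker inhibition of growth and lower numbers for stronger inhibition of growth. Compound 2 `N#Cc1ccc(Nc2nc(NCCCO)c3ccccc3n2)cc1` carries a cyano group and gives 23700 nM in this assay. Compound 3 `Nc1ccc(Nc2nc(NCCCO)c3ccccc3n2)cc1` carries an amino group and gives 19700 nM in this assay. Compound 3 is not set apart from the other two: the steps of a 1.0-fold lower number from compound 1 to compound 3 (0.01 log units; within the scatter) and a 1.2-fold lower number from compound 2 to compound 3 (0.08 log units; within the scatter) lie within the scatter, as does the step of a 1.2-fold higher number from compound 1 to compound 2 (0.07 log units; within the scatter).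

Compound 4 `OCCCNc1nc(Nc2ccc(F)cc2)nc2ccccc12` is reached from compound 3 by one change: fluoro in place of amino on an aromatic carbon. All three measured steps swap the group at this same place, and none of them moved the number beyond the scatter. On that basis the swap to fluoro is expected to leave the number unchanged beyond the scatter, which in this assay means an expected step of a 1.1-fold higher number from compound 3 to compound 4 (0.03 log units; within the scatter). Compound 4 is therefore estimated at 21000 nM, with a range from 10000 nM to 45000 nM.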

Compound 4, concentration for 50% growth inhibition: 17100 nM
Compound 4: middle estimate off by 1.2-fold (0.09 log units), on the high side; measured number inside the range.
By their numbers in this assay, from the lowest: compounds 4, 3, 1 and 2 (each within the scatter of the next).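

In this assay the steps of a 1.2-fold lower number from compound 3 to compound 4 (0.06 log units; within the scatter) and a 1.2-fold lower number from compound 1 to compound 4 (0.07 log units; within the scatter) and a 1.4-fold lower number from compound 2 to compound 4 (0.14 log units; within the scatter) all stay within the scatter, so fluoro joins amino, methoxy and cyano as a fourth group that cannot be told apart from the others at this position. The swap from amino to fluoro also takes the count from one hydrogen-bond donor and one hydrogen-bond acceptor to none of either, and even this leaves the number within the scatter. No measurement shown here explains why these four groups give such similar numbers.

From the compounds shown here alone, whether a carboxylic acid, a morpholine ring or a longer chain in this same place would shift the number remains open. So does whether any change to the shared core or to its hydroxyl-bearing side chain would do so.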